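A few compounds are considered here, and "the series" means these few. Any claim that something is new, unique, unknown or untested is made for them only; others in the source may bear on it.

Measured compounds:
- compound 1, `CCCCCCn1cc(COc2ccc(C(=O)/C=C/c3ccc(Cl)cc3)c(O)c2)nn1`, an ADME assay on cells (Macrophage) for cytotoxicity, read by resazurin assay, with a stated time of 48 h; on this read-out lower numbers stand for higher toxicity in this test and higher numbers for lower toxicity in this test: "not determined" (no result reported)
- compound 2, `CCCCCCn1cc(COc2ccc(C(=O)/C=C/c3ccccc3)c(O)c2)nn1`: "not determined" (no result reported)
- compound 3, `O=C(/C=C/c1c(F)cccc1Cl)c1ccc(OCc2cn(Cc3ccc(Br)cc3)nn2)cc1O`: 65800 nM

Compound 3 stands alone with a number in this assay; compound 1 and compound 2 carry the shared core but return no result, so nothing can be said of where compound 3 sits relative to them. With only one figure shown, no ordering among the measured compounds is possible.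

Compound 4, `CCCCCCn1cc(COc2ccc(C(=O)/C=C/c3c(F)cccc3Cl)c(O)c2)nn1`, is the compound to be measured in this assay. It differs from compound 3 in one place: pentyl in place of 4-bromophenyl on a saturated chain carbon bound to an aromatic nitrogen. The rest of the molecule, including the shared core with its fluorine and chlorine substituents on the outer ring, stays the same.

No step between two measured compounds is shown, so there is no measured precedent for a change of this kind in this assay. The change replaces one ring-bearing group with an open chain of the size counted above, and with nothing in the data to anchor a direction, the expectation is for a step from compound 3 to compound 4 that stays within the usual scatter. The expected step is a 1.1-fold lower number from compound 3 to compound 4 (0.04 log units; within the scatter). Compound 4 is therefore estimated at 60000 nM, with a range from 25000 nM to 150000 nM.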

Compound 4, half-maximal cytotoxic concentration: > 100000 nM
Compound 4: no number, only a limit; the forecaster's own chance of this, stated with the estimate: 30%; middle value at least 1.6-fold (0.22 log units) from the limit.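

In this assay compound 4 gives > 100000 nM, which is a limit of the assay and not a number. Pentyl in place of 4-bromophenyl on a saturated chain carbon bound to an aromatic nitrogen gives an at least 1.5-fold higher number from compound 3 to compound 4 (0.18 log units; that floor lies within the scatter), so this is the first reading at this position, and it shows that the open chain did not bring the number down, although the floor of the step does not by itself clear the usual scatter. The true size of the step stays unknown, since the comparison ends at the top of the read-out: the limit of > 100000 nM in this assay, at which 1 of the 4 values shown sits.

Compound 1 and compound 2 also carry the hexyl chain but give no result, so they cannot show whether the outer ring changes what this chain does. The compounds shown also leave open whether the ring or the bromine of the 4-bromobenzyl group accounts for the number of compound 3, and how an unsubstituted benzyl, a longer chain, or a chain ending in an amine or a carboxylic acid would read at this place.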